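Swapping a hydroxyl for a carboxyl on the amide arm

The compounds below may be only part of what the source reports. "The series", "measured", "known", "first", "only" and "open" are said of these compounds alone.

Compound 1 `CCn1c(C(=O)NCCNC(=O)OC(C)(C)C)ccc1C(CC)(CC)c1ccc(OCS(=O)(=O)c2ccccc2)c(C)c1`, compound 2 `CCn1c(C(=O)NCCN)ccc1C(CC)(CC)c1ccc(OCS(=O)(=O)c2ccccc2)c(C)c1` and compound 3 `CCn1c(C(=O)N[C@@H](C)CO)ccc1C(CC)(CC)c1ccc(OCS(=O)(=O)c2ccccc2)c(C)c1` share one core and differ only in the group carried on the amide-type nitrogen. In a functional assay on BXPC-3 cells (Homo sapiens) for antiproliferative activity, read by MTT assay, with a stated time of 24 h (a higher number here means a weaker inhibitor, a lower number a stronger inhibitor), compound 1 reaches the assay limit of > 50000 nM, a limit and not a number. Compound 2 gives 6430 nM. Compound 3 gives 15300 nM, the higher of the two real numbers, with a 2.4-fold higher number from compound 2 to compound 3 (0.38 log units; beyond the scatter). The steps of an at least 7.7-fold lower number from compound 1 to compound 2 (0.89 log units; beyond the scatter) and an at least 3.2-fold lower number from compound 1 to compound 3 (0.51 log units; beyond the scatter) both start from that limit. Compound 4 `CCn1c(C(=O)N[C@H](C)C(=O)O)ccc1C(CC)(CC)c1ccc(OCS(=O)(=O)c2ccccc2)c(C)c1` carries the change (1-carboxyethyl in place of 1-(hydroxymethyl)ethyl on an amide-type nitrogen). For the measured compounds named here, no measured step exchanges these two groups; the nearest comparison is the modest shift a 2.4-fold higher number from compound 2 to compound 3 (0.38 log units; beyond the scatter). The step of a 1.3-fold higher number from compound 3 to compound 4 (0.12 log units; within the scatter) is therefore expected to be small. Compound 4 is estimated at 20000 nM, between 7000 nM and 60000 nM.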

Compound 4, half-maximal inhibitory concentration: 20100 nM
For compound 4 the middle estimate is 1.0-fold (0.00 log units) below the measured one; the range from low to high includes it.
By their numbers in this assay, from the lowest: compound 2; then compounds 3 and 4 (each within the scatter of the next). At a limit, above all of these: compound 1.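

On the amide-type nitrogen, 1-carboxyethyl and 1-(hydroxymethyl)ethyl cannot be told apart here, with a 1.3-fold higher number from compound 3 to compound 4 (0.12 log units; within the scatter). The 2-aminoethyl group of compound 2 is the one that stands apart, with a 3.1-fold higher number from compound 2 to compound 4 (0.49 log units; beyond the scatter), so among these three free end groups only the amine gives a stronger inhibitor. The remaining step, an at least 2.4-fold lower number from compound 1 to compound 4 (0.39 log units; beyond the scatter), starts from a limit and not a number: the limit of > 50000 nM in this assay, at which 1 of the 4 values shown sits.

Still open, as far as these compounds go, is whether a 3-aminopropyl chain would match 2-aminoethyl. Also open, from the compounds shown here alone, is whether a methyl ester or primary amide in place of the carboxylic acid would read the same.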